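The source may report more compounds than this note shows. Statements on the series, on what has been measured and on what is new or still open speak of the compounds shown alone.

Three measured compounds share one core, each carrying a nitrile and two amine-linked side groups. Compound 2 `N#Cc1cnc(NCc2cnccc2C(F)(F)F)cc1NC[C@H]1CC[C@@H](O)CC1` gives 500 nM in an assay on isolated protein for inhibition of protein kinase C delta type (Homo sapiens), read by TR-FRET, with a stated time of 2 h (on this read-out higher numbers stand for weaker inhibition and lower numbers for stronger inhibition), the lowest of the three numbers. Compound 3 `COc1ncncc1CNc1cc(N[C@H]2CC[C@@H](O)CC2)c(C#N)cn1` gives 800 nM in this assay, a gap from compound 2 that stays within the usual scatter, so the two cannot be ranked against each other. Compound 1 `N#Cc1cnc(NCc2ccccc2C(F)(F)F)cc1N[C@H]1CC[C@@H](O)CC1` gives 4500 nM in this assay, a gap from compound 2 that lies well beyond the scatter.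

Compound 4 `CC1(C)C[C@H](Nc2cc(NCc3cnccc3C(F)(F)F)ncc2C#N)CC[C@H]1O` has not yet been measured. It differs from compound 2 in one place: 4-hydroxy-3,3-dimethylcyclohexyl in place of (4-hydroxycyclohexyl)methyl on a nitrogen on an aromatic ring. Among the compounds with values here, no measured pair isolates this change on its own, and the two added methyl groups have no precedent among the measured compounds. The step is expected to be modest and not clearly beyond the scatter, in either direction: a 1.2-fold higher number from compound 2 to compound 4 (0.08 log units; within the scatter). Compound 4 is therefore estimated to give 600 nM in this assay, with a likely range from 150 nM to 2500 nM.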

Compound 4, half-maximal inhibitory concentration: 2200 nM
For compound 4 the middle estimate is 3.7-fold (0.56 log units) below the measured one; measured number inside the range.
By their numbers in this assay, from the lowest: compounds 2 and 3 (each within the scatter of the next); then compound 4; then compound 1.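

The group on this nitrogen on an aromatic ring is not a neutral place to make changes: in this assay, replacing (4-hydroxycyclohexyl)methyl with 4-hydroxy-3,3-dimethylcyclohexyl gives a 4.4-fold higher number from compound 2 to compound 4 (0.64 log units; beyond the scatter). This single swap alters two things at once, removing the methyl link between the nitrogen and the ring and adding the 3,3-dimethyl groups to the ring, so the step belongs to the swap as a whole and not to either part. No measurement available here explains the step.

The compounds shown leave open which of the two parts accounts for the step, as none of them changes the link or the dimethyl groups alone. They also leave open how this position would respond if an amine took the place of the hydroxyl on the ring.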